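Series notes: alkenyl replacement on compound 1

The compounds below may be only part of what the source reports. "The series", "measured", "known", "first", "only" and "open" are said of these compounds alone.

compound 1 `O=c1[nH]c(=O)n([C@H]2C[C@H](O)[C@@H](CO)O2)cc1/C=C/I` — 63900 nM in an ADME assay on L1210/0 cells (Mus musculus) for cytotoxicity, with a stated time of 48 h; a lower number here means a stronger inhibitor, a higher number a weaker inhibitor
compound 2 `CO/N=C/C1CC(n2cnc3c(N)ncnc32)C(O)C1O` — > 200000 nM in this assay, which is a limit and not a number

Among the compounds with values here, compound 1 therefore stands as the only numeric value, the other entry being (the limit of > 200000 nM in this assay, at which 1 of the 2 values shown sits). Compound 3 `CCCC/C=C\c1cn([C@H]2C[C@H](O)[C@@H](CO)O2)c(=O)[nH]c1=O` awaits measurement; it differs from compound 1 by hex-1-en-1-yl in place of 2-iodoethenyl on an aromatic carbon. Within the data shown here, no measured step covers this change, so neither size nor direction is known; a step within the scatter or a modest loss is expected. Compound 3 is estimated at 90000 nM, with a range from 25000 nM to 300000 nM. The expected step is a 1.4-fold higher number from compound 1 to compound 3 (0.15 log units; within the scatter).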

Compound 3, half-maximal inhibitory concentration: > 200000 nM
Compound 3 was reported as a limit; the forecaster's own chance of this, stated with the estimate: 35%; middle value at least 2.2-fold (0.34 log units) away from the limit.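

Hex-1-en-1-yl in place of 2-iodoethenyl on this aromatic carbon gives the first measured step at this position in this assay, and the number moves towards weaker inhibition: an at least 3.1-fold higher number from compound 1 to compound 3 (0.49 log units; beyond the scatter). For compound 3, > 200000 nM is a limit and not a number. Compound 1 remains the only compound with a numeric value, and the limit now holds for most of the set: the limit of > 200000 nM in this assay, at which 2 of the 3 values shown sit.

Still open, going by these compounds, is how a shorter chain such as prop-1-en-1-yl behaves at this position. Also open, on these data alone, is whether bromine in place of iodine on the ethenyl group keeps a numeric value.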